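The source may report more compounds than this note shows. Statements on the series, on what has been measured and on what is new or still open speak of the compounds shown alone.

In a functional assay on K562 cells (Homo sapiens) for antiproliferative activity, read by MTT assay, with a stated time of 72 h (a higher number here means a weaker inhibitor, a lower number a stronger inhibitor), compound 1 `CN1CCN(c2cccc(C(=O)/C=C/c3ccc(/C=C/C(=O)NO)nc3)c2)CC1` gives 360 nM and compound 2 `CN1CCN(c2ccc(C(=O)/C=C/c3ccc(/C=C/C(=O)NO)nc3)cc2)CC1` gives 410 nM, two values within the usual scatter of each other. Compound 3 `O=C(/C=C/c1cccc(/C=C/C(=O)c2ccccc2)c1)NO` gives 3210 nM, the highest of the three numbers and beyond the scatter from both others, which makes it the weakest inhibitor of the group.

Compound 4 `CN1CCN(c2ccccc2C(=O)/C=C/c2cccc(/C=C/C(=O)NO)c2)CC1` comes from compound 3 through a single change: 4-methylpiperazin-1-yl in place of hydrogen on an aromatic carbon. A 4-methylpiperazin-1-yl takes the place of hydrogen on an aromatic carbon, ortho to a large group. Compound 1 and compound 2 also carry this group, but they differ from compound 3 in other ways too, so the data hold no direct measure of what this change alone does.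

Going by the values given here, the only guide is that compound 1, at 360 nM, and compound 2, at 410 nM, both carry the group and both have lower numbers than compound 3. A moderate fall beyond the scatter is therefore expected, with an estimated 3.6-fold lower number from compound 3 to compound 4 (0.55 log units; beyond the scatter). For compound 4 the estimated value is 900 nM, with an expected range of 280 nM to 2900 nM.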

Compound 4, half-maximal inhibitory concentration: 1290 nM
For compound 4 the middle estimate is 1.4-fold (0.16 log units) below the measured one, and the stated range covers the measured number.
By their numbers in this assay, from the lowest: compounds 1 and 2 (each within the scatter of the next); then compound 4; then compound 3.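

Going by these compounds alone, compound 1 and compound 2 carry the 4-methylpiperazin-1-yl group but differ from compound 3 in other ways too, so this is the first direct reading of that single change, and this assay shows a 2.5-fold lower number from compound 3 to compound 4 (0.40 log units; beyond the scatter) when the group replaces hydrogen on an aromatic carbon, ortho to a large group. The step is modest but beyond the scatter, so a group with a six-membered non-aromatic ring can sit at this place and the number still falls rather than rises. No measurement at hand bears on why the number falls.

Going by these compounds, it remains open whether this fall needs the whole 4-methylpiperazin-1-yl group or would also come with a smaller dimethylamino group or a morpholine ring at the same place. The effect of the same group on the other carbons of this ring, with the rest of compound 4 unchanged, also stays unresolved.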